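This account rests on a few compounds, and the source may have more. Where it says the series, first, only, none or still open, it means among the compounds named here.

Compound 2 `O=c1cc(CNCc2cccc(O)c2)oc2ccc(O)c(O)c12` stands in an ADME assay on Huh-7 cells (Homo sapiens) for cytotoxicity (on this read-out higher numbers stand for lower toxicity in this test and lower numbers for higher toxicity in this test), only at a limit of the assay, > 100000 nM. Compound 1 `O=c1cc(CNCc2cccc(I)c2)oc2ccc(O)c(O)c12` likewise gives only the limit > 100000 nM in this assay. Among the compounds with values here, the one measured step, a step that the two limits leave unreadable from compound 1 to compound 2, cannot be read because both values sit at the limit of > 100000 nM in this assay, at which 2 of the 2 values shown sit. Compound 3 `O=c1cc(CNCc2ccc(I)cc2)oc2ccc(O)c(O)c12` carries 4-iodophenyl in place of 3-hydroxyphenyl on a saturated chain carbon bound to an amine nitrogen. Within the data shown here, no measured step reads directly on this change; compound 1, itself iodo-bearing, already rests at the limit. Compound 3 is expected to stay at the limit in this assay, the step that the limit leaves unreadable from compound 2 to compound 3 being no more than scatter. The estimate for compound 3 is 150000 nM, from 60000 nM to 400000 nM.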

Compound 3, half-maximal cytotoxic concentration: 41700 nM
Estimate against measurement, compound 3: 3.6-fold (0.56 log units) above; the measured number lies below the stated range.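

Compound 3 gives the first value inside the range of this assay in this series, with an at least 2.3-fold lower number from compound 2 to compound 3 (0.37 log units; beyond the scatter) and with an at least 2.3-fold lower number from compound 1 to compound 3 (0.37 log units; beyond the scatter) as the two readable steps. The second step keeps iodine and exchanges only 3-iodophenyl for 4-iodophenyl, so the presence of iodine alone does not set the read-out at this place. Going by these compounds, both steps start from a limit, so their full size stays unknown. Open, on these data alone, is whether the lower number is tied to iodine or would also appear with 4-bromophenyl or 4-methoxyphenyl.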